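The source may hold more compounds than are shown below. What is called first, only, known or untested is meant among the compounds shown, and "the series" means these compounds.

Of the compounds shown here, three sharing one core have been measured in an in vivo ADME assay on the whole organism for pharmacokinetics, with Rattus norvegicus as the target; a lower number here means that the compound disappears faster, a higher number that the compound lasts longer. Compound 1 `COc1cc(C#N)c(NC(=O)c2sccc2S(=O)(=O)Nc2onc(C)c2Cl)c(OC)c1OC` gives < 1 h, which is a limit of the assay and not a number. Compound 2 `Cc1cc(C)c(NC(=O)c2sccc2S(=O)(=O)Nc2onc(C)c2Cl)c(C)c1C#N` has a half-life of 1.8 h. Compound 3 `Cc1cc(C)c(S(N)(=O)=O)c(C)c1NC(=O)c1sccc1S(=O)(=O)Nc1onc(C)c1Cl` has a half-life of 1.5 h, and these two numbers lie within the scatter of each other, so compound 2 stands level with compound 3 among the numbered results.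

The next structure is compound 4 `CC(=O)OCc1c(C)cc(C)c(NC(=O)c2sccc2S(=O)(=O)Nc2onc(C)c2Cl)c1C`, which carries acetoxymethyl in place of cyano on an aromatic carbon of compound 2: acetoxymethyl in place of cyano on an aromatic carbon. Among the compounds with values here, one measured step bears on this change, a 1.2-fold lower number from compound 2 to compound 3 (0.08 log units; within the scatter), where sulfamoyl took the place of cyano on an aromatic carbon. Within the data shown here, that single step stayed within the scatter, but sulfamoyl is not acetoxymethyl, and the data hold no measured compound that carries the entering group. No change beyond the scatter is therefore expected in this assay, though the range has to stay wide. The expected change is a 1.2-fold lower number from compound 2 to compound 4 (0.08 log units; within the scatter), which is no real step in either direction. For compound 4 the estimated half-life is 1.5 h, with an expected range from 0.7 h to 3.2 h.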

Compound 4, half-life: 0.5 h
Beside the measured number, compound 4's estimate is 3.0-fold (0.48 log units) above it; the measured number lies below the stated range.
By their numbers in this assay, from the lowest: compound 4; then compounds 3 and 2 (each within the scatter of the next).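

In this assay, the aromatic carbon ortho to two methyl groups and para to a methyl group now proves sensitive to the group it carries: acetoxymethyl in place of cyano gives a 3.6-fold lower number from compound 2 to compound 4 (0.56 log units; beyond the scatter), whereas sulfamoyl in place of cyano gave only a 1.2-fold lower number from compound 2 to compound 3 (0.08 log units; within the scatter). Acetoxymethyl in place of sulfamoyl gives a 3.0-fold lower number from compound 3 to compound 4 (0.48 log units; beyond the scatter), so compound 4 stands apart from both compound 2 and compound 3, which remain within the scatter of each other. This is one entering group at one position, so it sets up no general pattern, and the data do not tell which part of acetoxymethyl goes with the lower number.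

From the compounds shown here alone, it remains open whether hydroxymethyl, methoxymethyl or a carboxylic acid on this carbon would read like acetoxymethyl or like cyano. Compound 1 remains a limit and not a number, so its place in the order stays open: the limit of < 1 h in this assay, at which 1 of the 4 values shown sits.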